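The source may report more compounds than this note shows. Statements on the series, on what has been measured and on what is new or still open speak of the compounds shown alone.

In a physicochemical assay for solubility, read by HPLC, in phosphate buffer, measured as kinetic solubility, with a stated time of 1 h, at pH 7.4, tested at 250 uM (a lower number here means a less soluble compound, a higher number a more soluble compound), compound 1 `CCOCCNC(=O)n1cc(-c2ccccc2)oc1=O` gives 20000 nM. Compound 2 `COc1cccc(-c2cn(C(=O)NCCCCc3ccccc3)c(=O)o2)c1` gives < 1000 nM, and this reading is a limit of the assay and not a number. For the measured compounds named here, it is the only reading of the pair that sits at the limit of < 1000 nM in this assay, at which 1 of the 2 values shown sits, so compound 2 has no exact position on the scale. Compound 3 `O=C(NCCCCc1ccccc1)n1cc(-c2cccnc2)oc1=O` keeps the rest of compound 2 and carries pyridin-3-yl in place of 3-methoxyphenyl on an aromatic carbon. Going by the values given here, no measured pair of compounds shows this change or any other single change, so the expectation rests on the structural change alone. A moderate rise beyond the usual scatter is expected in this assay, with an estimated at least 4.0-fold higher number from compound 2 to compound 3 (0.60 log units; beyond the scatter). For compound 3 the estimated solubility is 4000 nM, within an expected range of 1000 nM to 20000 nM.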

Compound 3, solubility: < 1000 nM
Compound 3: only a limit was reported; the forecaster's own chance of this, stated with the estimate: 30%; middle value at least 4.0-fold (0.60 log units) away from the limit.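

In this assay compound 2 and compound 3 both read as limits and not as numbers, so no step can be read between them: the limit of < 1000 nM in this assay, at which 2 of the 3 values shown sit. The compounds shown leave open how far apart compound 2 and compound 3 lie, and whether pyridin-3-yl in place of 3-methoxyphenyl shifts the reading at all.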